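The source may hold more compounds than are shown below. What is called first, only, known or untested is meant among the compounds shown, and "the series" means these compounds.

Within the data shown here, compound 1 `CCCCCCCCCCCOc1ccccc1C(SCCC(=O)O)SCCC(=O)O` holds the only plain number in an assay on membranes from lung (Cavia porcellus) for binding affinity to cysteinyl leukotriene receptor (Homo sapiens) (on this read-out lower numbers stand for stronger inhibition and higher numbers for weaker inhibition), where compound 1 gives 287 nM. Compound 2 `CCOCCOCCOCCOc1ccccc1C(SCCC(=O)O)SCCC(=O)O` in this assay gives only a limit, > 20000 nM. Compound 3 `CCCCCCCCCCCOc1ccccc1C(C)(SCCC(=O)O)SCCC(=O)O` in this assay likewise gives only a limit, > 20000 nM. The step of an at least 69-fold higher number from compound 1 to compound 2 (1.84 log units; beyond the scatter) and the step of an at least 69-fold higher number from compound 1 to compound 3 (1.84 log units; beyond the scatter) are both large, and both end at the limit of > 20000 nM in this assay, at which 2 of the 3 values shown sit. Compound 4 `CCCCCCCCCCCOc1ccc(O)cc1C(SCCC(=O)O)SCCC(=O)O` carries hydroxy in place of hydrogen on an aromatic carbon. From the compounds shown here alone, neither measured step alters the aromatic ring; none of them bears directly on this change, and a moderate step in either direction, or none beyond the scatter, remains open. For compound 4 a step of a 1.7-fold higher number from compound 1 to compound 4 (0.24 log units; within the scatter) is expected, toward a somewhat higher number. Compound 4 is estimated at 500 nM, within 100 nM to 3000 nM.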

Compound 4, inhibition constant: 156 nM
The estimate for compound 4 lay 3.2-fold (0.51 log units) above the measured number; the measured number falls inside the stated range.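

In this assay, hydroxy on this aromatic carbon, meta to a large group and para to a large group, gives a 1.8-fold lower number from compound 1 to compound 4 (0.26 log units; within the scatter), so the position accepts the added group with no change beyond the scatter. This is the only change shown on the aromatic ring, and compound 4 keeps a plain number, unlike the changes made elsewhere on compound 1: the limit of > 20000 nM in this assay, at which 2 of the 4 values shown sit.

From the compounds shown here alone, whether methoxy, fluorine or an amine at this carbon would match hydroxy remains open. So does the effect of hydroxy on the other aromatic carbons.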